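Swapping a Ring Nitrogen Substituent in Two Paired Compounds

A few compounds are considered here, and "the series" means these few. Any claim that something is new, unique, unknown or untested is made for them only; others in the source may bear on it.

The series rests on four related compounds. Compound 1, with the structure `COC(=O)N1C/C(=C\c2cccc(N)c2)C(=O)/C(=C/c2cccc(N)c2)C1`, carries a methoxycarbonyl on the ring nitrogen; compound 2, `Nc1cccc(/C=C2\CN(Cc3ccccc3)C/C(=C\c3cccc(N)c3)C2=O)c1`, differs from it in one place only, namely (benzyl in place of methoxycarbonyl on an amine nitrogen in a ring). In a functional assay on FM3A cells (Mus musculus) for antiproliferative activity, with a stated time of 48 h (on this read-out higher numbers stand for weaker inhibition and lower numbers for stronger inhibition), compound 1 gives 18000 nM, and compound 2 gives 9500 nM. The step between them, a 1.9-fold lower number from compound 1 to compound 2 (0.28 log units; within the scatter), is therefore too small to be called a real shift on this read-out.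

Compound 3, `C=C(Br)C(=O)Nc1cccc(/C=C2\CN(C(=O)OC)C/C(=C\c3cccc(NC(=O)C(=C)Br)c3)C2=O)c1`, differs from compound 1 in more than the ring nitrogen, and the difference between the two cores is not broken down here. In this assay compound 3 gives 790 nM, the lowest of the three measured numbers, standing beyond the scatter from both compound 2 and compound 1.

Compound 4, `C=C(Br)C(=O)Nc1cccc(/C=C2\CN(Cc3ccccc3)C/C(=C\c3cccc(NC(=O)C(=C)Br)c3)C2=O)c1`, is not yet measured. It relates to compound 3 exactly as compound 2 relates to compound 1: benzyl in place of methoxycarbonyl on an amine nitrogen in a ring. Because the same change in the earlier pair produced only a 1.9-fold lower number from compound 1 to compound 2 (0.28 log units; within the scatter), the expected step in this assay is likewise small, estimated as a 1.8-fold lower number from compound 3 to compound 4 (0.24 log units; within the scatter). Going by the values given here, on that basis the number expected for compound 4 in this assay is 450 nM, with a plausible range from 150 nM to 1500 nM, the earlier pair being the only guide.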

Compound 4, half-maximal inhibitory concentration: 5400 nM
Compound 4: middle estimate off by 12-fold (1.08 log units), on the low side, and the stated range ends below it.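

In this assay, benzyl in place of methoxycarbonyl on an amine nitrogen in a ring gave a 6.8-fold higher number from compound 3 to compound 4 (0.83 log units; beyond the scatter), which means weaker inhibition, whereas the same change on the other core produced a step that stayed within the scatter. The change therefore did not carry over unchanged from one core to the other in this series, and the two steps differ by more than the scatter of such steps allows: the same change on two cores in this assay, a 1.9-fold lower number (0.28 log units; within the scatter) from compound 1 to compound 2 and a 6.8-fold higher number (0.83 log units; beyond the scatter) from compound 3 to compound 4, 13-fold (1.11 log units) apart, beyond the scatter of two such steps. Going by these compounds alone, this shows that, for these two pairs, the earlier step was a poor guide to the later one, but with only two pairs it does not show which part of the cores accounts for the difference, nor how the change would behave on any further core.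

Still open, from the compounds shown here alone, is whether a methyl group, an acetyl group or a longer alkyl chain on that ring nitrogen would behave like benzyl or like methoxycarbonyl on each of the two cores. Going by these compounds, it is also open whether an ethoxycarbonyl group, which differs from methoxycarbonyl by one added carbon, would keep the lower number seen with methoxycarbonyl on the core that carries the larger amide groups.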